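Urea series: phenyl to benzyl on the amide-type nitrogen

This account rests on a few compounds, and the source may have more. Where it says the series, first, only, none or still open, it means among the compounds named here.

Measured in a functional assay on U-373MG ATCC cells (Homo sapiens) for inhibition, read by MTT assay, with a stated time of 72 h; a lower number here means a stronger inhibitor, a higher number a weaker inhibitor:
- compound 1 `CC1(C)CC(NC(=O)Nc2ccccc2Cl)c2cc(F)ccc2O1`: 40000 nM
- compound 2 `CC1(C)CC(NC(=O)Nc2ccccc2)c2cc(Cl)ccc2O1`: 68000 nM

In this assay compound 2 at 68000 nM and compound 1 at 40000 nM lie within the usual scatter of each other, so the two cannot be ranked.

Compound 3 `CC1(C)CC(NC(=O)NCc2ccccc2)c2cc(Cl)ccc2O1` is the next point to consider. Its difference from compound 2 is benzyl in place of phenyl on an amide-type nitrogen. Among the compounds with values here, no pair of measured compounds shows a change in one place, so the series offers no measured guide to this step. Within the data shown here, the only anchor is compound 2 at 68000 nM, and no change beyond the scatter is expected, in either direction. The expected change is a 1.1-fold lower number from compound 2 to compound 3 (0.05 log units; within the scatter). The estimate for compound 3 is 60000 nM, with an expected range from 25000 nM to 120000 nM.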

Compound 3, half-maximal inhibitory concentration: 66000 nM
Compound 3: middle estimate off by 1.1-fold (0.04 log units), on the low side, within the range that was stated.
By their numbers in this assay, from the lowest: compounds 1, 3 and 2 (each within the scatter of the next).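

In this assay, the series now has its first step in a single place: benzyl in place of phenyl on an amide-type nitrogen gives a 1.0-fold lower number from compound 2 to compound 3 (0.01 log units; within the scatter). This step lies within the scatter, so compound 2 and compound 3 cannot be told apart, and anilino and benzylamino read alike at this nitrogen on the core shared by these two compounds. No measurement at hand accounts for this result.

From the compounds shown here alone, it remains open whether a longer chain such as phenethyl, or a benzyl group carrying an amine or a carboxylic acid, would give a step beyond the scatter at this nitrogen. Going by these compounds, it is also open whether the change from phenyl to benzyl would read the same way in the setting of compound 1.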